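Thiophen-2-yl for phenyl on the trifluoroethyl compound

The source may report more compounds than this note shows. Statements on the series, on what has been measured and on what is new or still open speak of the compounds shown alone.

In an ADME assay on microsomes from liver (Rattus norvegicus) for metabolic stability, read by LC-MS, using NADPH, tested at 3 uM (a lower number here means that the compound disappears faster, a higher number that the compound lasts longer), compound 3 (`Cc1ccc2c(C(CC(F)(F)F)c3ccccc3)c(-c3ccccc3)[nH]c2c1`) gives 0.47 h and compound 2 (`Cc1ccc2c(C(C(=O)C(F)(F)F)c3ccccc3)c(-c3ccccc3)[nH]c2c1`) gives 0.413 h, so these two stand level within the scatter. Compound 1 (`Cc1ccc2c(C(c3cccs3)C(C#N)C#N)c(-c3ccccc3)[nH]c2c1`) gives 0.0817 h, a lower number than either.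

Compound 4 (`Cc1ccc2c(C(CC(F)(F)F)c3cccs3)c(-c3ccccc3)[nH]c2c1`) has not been measured. It keeps the 2,2,2-trifluoroethyl group of compound 3 and changes the other substituent: thiophen-2-yl in place of phenyl on a saturated chain carbon bound to an aromatic carbon and a saturated chain carbon. This puts thiophen-2-yl in place of phenyl on a saturated chain carbon bound to an aromatic carbon and a saturated chain carbon.

Within the data shown here, no measured pair isolates this swap. Among the measured compounds shown here, the one measured step, a 1.1-fold higher number from compound 2 to compound 3 (0.06 log units; within the scatter), concerns a different group and is small, so it shows only that the number held steady at that place. For the measured compounds named here, the sole measured compound with thiophen-2-yl is compound 1 at 0.0817 h, but it also differs from compound 3 in the other group, so its low number cannot be assigned to the ring. It supports only a slight lean downward, and no step beyond the scatter is firmly expected.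

The estimated step is a 1.6-fold lower number from compound 3 to compound 4 (0.19 log units; within the scatter). For compound 4 the expected half-life is 0.3 h, with an estimated range of 0.12 h to 0.65 h.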

Compound 4, half-life: 0.292 h
The estimate for compound 4 lay 1.0-fold (0.01 log units) above the measured number; low and high end bracket the measured number.
By their numbers in this assay, from the lowest: compound 1; then compounds 4, 2 and 3 (each within the scatter of the next).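

In this assay the swap of thiophen-2-yl for phenyl now has a measured pair, and a 1.6-fold lower number from compound 3 to compound 4 (0.21 log units; within the scatter) places the two compounds level within the scatter, so on this saturated chain carbon the thiophen-2-yl ring is tolerated as well as phenyl. Among these compounds, with thiophen-2-yl held constant, the other group can be read for the first time: 2,2,2-trifluoroethyl in place of dicyanomethyl gives a 3.6-fold higher number from compound 1 to compound 4 (0.55 log units; beyond the scatter) and this step lies beyond the scatter. The short half-life of compound 1 therefore goes with its dicyanomethyl group and cannot be laid on the ring, though no measurement shown here speaks to the reason for either step.

From the compounds shown here alone, it remains open whether furan-2-yl or pyridin-2-yl would stand level with phenyl at this place, and whether the level reading for thiophen-2-yl against phenyl also holds with dicyanomethyl on the chain. Going by these compounds, it also remains open where a carboxylic acid, an amine or a longer fluorinated chain in place of 2,2,2-trifluoroethyl would fall relative to compound 1 and compound 4.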